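Swapping one group for chloro on compound 3

A few compounds are considered here, and "the series" means these few. Any claim that something is new, unique, unknown or untested is made for them only; others in the source may bear on it.

Compound 1 `CS(=O)(=O)c1ccc(-c2[nH]ccc2-c2ccc(F)cc2)cc1` gives > 317 uM (a limit)
Compound 2 `CS(=O)(=O)c1ccc(-c2[nH]c(Cl)c(Br)c2-c2ccc(F)cc2)cc1` gives 7.93 uM (a number)
Compound 3 `CS(=O)(=O)c1ccc(-c2[nH]c(C(=O)C(F)(F)F)cc2-c2ccc(F)cc2)cc1` gives 47.2 uM (a number)

In a functional assay on the whole organism with Rattus norvegicus as the target (a higher number here means that more compound is needed for the effect, a lower number that less compound is needed), compound 1 sits at a limit of the assay (> 317 uM) and has no exact number. Of the two exact numbers, compound 3 (47.2 uM) holds the higher one.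

Compound 4 (`CS(=O)(=O)c1ccc(-c2[nH]c(Cl)cc2-c2ccc(F)cc2)cc1`) carries chloro in place of (trifluoromethyl)carbonyl on an aromatic carbon next to the ring nitrogen (chloro in place of (trifluoromethyl)carbonyl on an aromatic carbon). Within the data shown here, one measured step bears on this carbon: adding that group there gave an at least 6.7-fold lower number from compound 1 to compound 3 (0.82 log units; beyond the scatter) as its size. Compound 2 (7.93 uM) also has chloro there, alongside one more group. In this assay the expected step is small (a 1.6-fold lower number from compound 3 to compound 4 (0.20 log units; within the scatter)) and toward a lower number, within the scatter. The estimate is that compound 4 gives 30 uM within a range from 8 uM to 110 uM (both ends estimated).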

Compound 4, concentration for half-maximal effect: 1.43 uM
Compound 4: the middle estimate sits 21-fold (1.32 log units) above what was measured; the whole stated range lies above it.
By their numbers in this assay, from the lowest: compound 4; then compound 2; then compound 3. At a limit, above all of these: compound 1.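

On the aromatic carbon next to the ring nitrogen, the choice of group matters greatly: chloro in place of (trifluoromethyl)carbonyl gives a 33-fold lower number from compound 3 to compound 4 (1.52 log units; beyond the scatter). Bromo is not needed for a low number either, since hydrogen in its place gives a 5.5-fold lower number from compound 2 to compound 4 (0.74 log units; beyond the scatter). Chloro in place of hydrogen gives an at least 220-fold lower number from compound 1 to compound 4 (2.34 log units; beyond the scatter), a size that is only a bound set by a limit of the assay: the limit of > 317 uM in this assay, at which 1 of the 4 values shown sits.

Going by these compounds, whether a methyl group, an amine or a carboxylic acid on this carbon would match chloro stays open. These numbers also do not tell why chloro gives the lower number.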